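The source may hold more compounds than are shown below. What is called first, only, known or untested is meant among the compounds shown, and "the series" means these compounds.

Compound 2 `CC(C)(C)Cc1c(-c2cccnc2)sc(N)c1C(=O)c1ccc(Cl)cc1` carries a pyridin-3-yl group where compound 1 `CC(C)(C)Cc1c(-c2ccoc2)sc(N)c1C(=O)c1ccc(Cl)cc1` carries furan-3-yl. In an assay on CHO cells for displacement of a labelled ligand from adenosine receptor A1 (Homo sapiens), read by scintillation counting, tested at 10 uM (on this read-out lower numbers stand for less inhibition and higher numbers for more inhibition at the one concentration tested (going by the name of the read-out)), compound 1 gives 1%, and compound 2 gives 1%; the step of no change at the digits printed from compound 1 to compound 2 (within the scatter) shows that swapping a five-membered aromatic ring for a six-membered one with a nitrogen left the read-out unchanged. On these numbers compound 2 stands level with compound 1, both at the bottom of the scale. Compound 3 `CC(C)(C)Cc1c(-c2ccc(F)cc2)sc(N)c1C(=O)c1ccc(Cl)cc1` differs from compound 2 in one place: 4-fluorophenyl in place of pyridin-3-yl on an aromatic carbon. For the measured compounds named here, the only measured step, the one from compound 1 to compound 2, exchanged the same ring and stayed within the scatter. The data hold nothing suggesting that a six-membered aromatic ring of carbon only would behave differently. Compound 3 is therefore expected to remain within the scatter of compound 2, a step of a number 1 percentage points higher from compound 2 to compound 3 (within the scatter) in this assay. The estimate for compound 3 is 2%, with a range from -6% to 12%.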

Compound 3, a percentage reported as inhibition, at one concentration (the size of the read-out at that concentration, not a potency): 1%
The estimate for compound 3 lay 1 percentage points above the measured number, and the stated range covers the measured number.
By their numbers in this assay, from the lowest: compounds 1, 2 and 3 (each within the scatter of the next).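

At this position, on the aromatic carbon next to the ring sulfur, this assay now shows no change at the digits printed from compound 2 to compound 3 (within the scatter) and also no change at the digits printed from compound 1 to compound 3 (within the scatter). The position has thus carried a six-membered aromatic ring of carbon only with a fluorine, a six-membered aromatic ring with a nitrogen and a five-membered furan-3-yl ring, and all three compounds sit level at the bottom of the scale, so neither the ring hetero atom nor the counted hydrogen-bond acceptor goes with any visible change in this read-out. No measurement at hand bears on why the read-out stays at this level.

The compounds shown leave open whether a non-aromatic group on this carbon, such as an amine or a carboxylic acid, would lift the read-out off the bottom of the scale. They also leave open whether a longer chain in place of the neopentyl group would do so.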